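Chloro in place of nitro in the series

The source may hold more compounds than are shown below. What is called first, only, known or untested is meant among the compounds shown, and "the series" means these compounds.

Measured so far in a functional assay on PANC-1 cells (Homo sapiens) for antiproliferative activity, read by CCK-8 assay, with a stated time of 72 h (a higher number here means a weaker inhibitor, a lower number a stronger inhibitor), as follows
- compound 1 `COc1cccc(Nc2nc(Nc3cc(C)[nH]n3)cc(N3CCN(C)CC3)n2)c1` gives 693 nM
- compound 2 `Cc1cc(Nc2cc(N3CCN(C)CC3)nc(Nc3cccc([N+](=O)[O-])c3)n2)n[nH]1` gives 457 nM

Among the measured compounds shown here, compound 2 stands within the scatter of compound 1, the only other compound measured. Next is compound 3 `Cc1cc(Nc2cc(N3CCN(C)CC3)nc(Nc3cccc(Cl)c3)n2)n[nH]1` with the change chloro in place of nitro on an aromatic carbon in these words: chloro in place of nitro on an aromatic carbon. For the measured compounds named here, the only measured step bearing on it is a 1.5-fold lower number from compound 1 to compound 2 (0.18 log units; within the scatter) for nitro in place of methoxy on an aromatic carbon, and it stays within the scatter. No step beyond the scatter is therefore expected in this assay, and no direction can be drawn. The estimated outcome is a 1.1-fold higher number from compound 2 to compound 3 (0.04 log units; within the scatter) (within the scatter). The expected value for compound 3 is 500 nM (estimated range 200 nM to 1300 nM).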

Compound 3, half-maximal inhibitory concentration: 351 nM
The estimate for compound 3 lay 1.4-fold (0.15 log units) above the measured number; low and high end bracket the measured number.
By their numbers in this assay, from the lowest: compounds 3, 2 and 1 (each within the scatter of the next).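

In this assay, chloro in place of nitro gives a 1.3-fold lower number from compound 2 to compound 3 (0.11 log units; within the scatter), although chloro brings 1 heavy atom and 0 hydrogen-bond acceptors where nitro has 3 and 2. Chloro in place of methoxy gives a 2.0-fold lower number from compound 1 to compound 3 (0.30 log units; within the scatter), so methoxy, nitro and chloro on this aromatic carbon cannot be told apart in these data. No evidence is available to explain this result.

On these data alone, whether an amine, a carboxylic acid or a longer chain at this place would give a step beyond the scatter remains open.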